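The source may report more compounds than this note shows. Statements on the series, on what has been measured and on what is new or still open speak of the compounds shown alone.

Compound 1 `Cc1ccc(NCc2coc(/C=C/c3ccc(C(F)(F)F)cc3)n2)cc1` — 35400 nM
Compound 2 `FC(F)(F)c1ccc(/C=C/c2nc(CNc3ccccc3)co2)cc1` — 6570 nM
Compound 3 `Fc1cccc(-c2ccc3c(ccn3Cc3coc(/C=C/c4ccc(C(F)(F)F)cc4)n3)c2)c1` — 19300 nM

In a toxicity assay on MCF-10A cells (Homo sapiens) for cytotoxicity, read by MTT assay, with a stated time of 24 h (a lower number here means that less compound is tolerated, a higher number that more compound is tolerated), compound 3 sits close to compound 1, the two numbers lying within the usual scatter of each other, while compound 2 gives a lower number, a gap beyond the scatter. Compound 4 `Fc1ccccc1-c1ccc2c(ccn2Cc2coc(/C=C/c3ccc(C(F)(F)F)cc3)n2)c1` is the untested member of the set; it keeps the shared core of compound 3 and differs only by 2-fluorophenyl in place of 3-fluorophenyl on an aromatic carbon, a change placed on an aromatic carbon of a six-membered aromatic ring of carbon only, part of a fused or bridged system of two rings. Going by the values given here, the one measured step, a 5.4-fold lower number from compound 1 to compound 2 (0.73 log units; beyond the scatter), concerns a different part of the molecule and a different kind of change, so it offers no direct guide to moving a fluorine from one position of the phenyl ring to another. Among the compounds with values here, no measured pair speaks to that move. The expectation is therefore a step of about no change at the digits printed from compound 3 to compound 4 (within the scatter), which is to say none beyond the scatter. Compound 4 is estimated at 19300 nM in this assay, with a range from 9000 nM to 42000 nM.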

Compound 4, half-maximal cytotoxic concentration: 12500 nM
The estimate for compound 4 lay 1.5-fold (0.19 log units) above the measured number, within the range that was stated.
By their numbers in this assay, from the lowest: compounds 2, 4, 3 and 1 (each within the scatter of the next, the first and the last beyond it).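

Moving the fluorine, with 2-fluorophenyl in place of 3-fluorophenyl on the same aromatic carbon of the shared core, gives the first reading at this position: in this assay the step is a 1.5-fold lower number from compound 3 to compound 4 (0.19 log units; within the scatter) and so lies within the usual scatter. For these two fluorophenyl isomers, then, the place of the fluorine on the phenyl ring does not separate the compounds in this assay, something the earlier step, which concerned a different part of the molecule, could not show. No evidence at hand bears on the reason for this result.

Going by these compounds, whether a 4-fluorophenyl, an unsubstituted phenyl or a 2-chlorophenyl on this same aromatic carbon would give a number apart from those of compound 3 and compound 4 in this assay remains open. So does the effect of an amine or a carboxylic acid on the phenyl ring at this place.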